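The source may hold more compounds than are shown below. What is called first, only, known or untested is meant among the compounds shown, and "the series" means these compounds.

Compound 1 `CC(C)C[C@H](NC(=O)N1CCOCC1)C(=O)N[C@@H](C)C#N` gives 142 nM in an assay for inhibition of cathepsin S (Homo sapiens); on this read-out lower numbers stand for stronger inhibition and higher numbers for weaker inhibition.
Compound 2 `CCCC[C@@H](C#N)NC(=O)[C@H](CC(C)C)NC(=O)N1CCOCC1` gives 56 nM in this assay.
Compound 3 `CC(C)C[C@H](NC(=O)N1CCOCC1)C(=O)NC(C)(C)C#N` gives 114 nM in this assay.

Compound 3 stands second highest of the three numbers: compound 1 lies within the scatter of it, while compound 2 sits lower, a 2.0-fold higher number from compound 2 to compound 3 (0.31 log units; beyond the scatter). Compound 4 `CC(C)(C#N)NC(=O)[C@H](CC1CCCCC1)NC(=O)N1CCOCC1` differs from compound 3 by cyclohexyl in place of isopropyl on a saturated chain carbon, two bonds along the chain from an amide-type nitrogen and a carbonyl carbon. Going by the values given here, none of the measured steps touches that place: a 2.5-fold lower number from compound 1 to compound 2 (0.40 log units; beyond the scatter) and a 1.2-fold lower number from compound 1 to compound 3 (0.10 log units; within the scatter) both concern the group on the amide-type nitrogen that carries the nitrile. Among the compounds with values here, no step in these data therefore speaks directly to the change, and the expectation for compound 4 in this assay rests only on the modest size of the steps seen so far. A modest step, or none beyond the scatter, is expected. Compound 4 is therefore estimated at 70 nM, in the range 20 nM to 250 nM, an expected step of a 1.6-fold lower number from compound 3 to compound 4 (0.21 log units; within the scatter).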

Compound 4, half-maximal inhibitory concentration: 17 nM
Compound 4: the middle estimate sits 4.1-fold (0.61 log units) above what was measured, and the stated range ends above it.
By their numbers in this assay, from the lowest: compound 4; then compound 2; then compounds 3 and 1 (each within the scatter of the next).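

Going by these compounds alone, exchanging isopropyl for cyclohexyl on the saturated chain carbon gives a 6.7-fold lower number from compound 3 to compound 4 (0.83 log units; beyond the scatter) in this assay and is the only measured change at this place. This step is larger than any step among the first three compounds, all of which differ in the group on the amide-type nitrogen that carries the nitrile, so this position moves the number further than that group does in these compounds. Nothing available explains the gain.

The compounds shown leave open whether the ring or the added carbons account for the step, which a straight hexyl chain or a phenyl ring at this place could test. Going by these compounds, whether the step holds with 1-cyanopentyl on the amide-type nitrogen also stays open.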